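Bromo for Methoxy on the Aryl Ring of Compound 3

A few compounds are considered here, and "the series" means these few. Any claim that something is new, unique, unknown or untested is made for them only; others in the source may bear on it.

Three hydroxamic acids sharing one core have been measured in an assay on Sf9 cells for inhibition of protein deacetylase HDAC6 (Homo sapiens), read by fluorescence, with a stated time of 40 min, tested at 100 nM; on this read-out lower numbers stand for less inhibition and higher numbers for more inhibition at the one concentration tested (going by the name of the read-out). Compound 1 `O=C(NO)c1ccc(NCc2nc(-c3ccccc3)nn2-c2ccccc2Cl)cc1` gives 64.6%, compound 2 `Cc1ccccc1-n1nc(-c2ccccc2)nc1CNc1ccc(C(=O)NO)cc1` gives 57.1%, and compound 3 `COc1ccc(-n2nc(-c3ccccc3)nc2CNc2ccc(C(=O)NO)cc2)cc1` gives 63.4%. Compound 3 thus stands second highest of the three, with compound 1 nearest and compound 2 furthest, though every gap among them lies within the scatter: a number 7.5 percentage points lower from compound 1 to compound 2 (within the scatter), a number 1.2 percentage points lower from compound 1 to compound 3 (within the scatter) and a number 6.3 percentage points higher from compound 2 to compound 3 (within the scatter).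

The next compound, compound 4 `O=C(NO)c1ccc(NCc2nc(-c3ccccc3)nn2-c2ccc(Br)cc2)cc1`, differs from compound 3 by a change on the aryl group bound to the aromatic nitrogen: bromo in place of methoxy on an aromatic carbon. Cut one bond further out, this reads 4-methoxyphenyl to 4-bromophenyl. Within the data shown here, the steps that bear on it are the two that exchange this same aryl group, from compound 1 to compound 3 and from compound 2 to compound 3, and both stayed within the scatter; the chloro-to-methyl step from compound 1 to compound 2 did likewise. Exchanges of this aryl group have so far not moved the read-out in this assay beyond the scatter, so no step beyond the scatter is expected here either.

Compound 4 is therefore expected to give 62%, within 48% to 76%, and the step of a number 1.4 percentage points lower from compound 3 to compound 4 (within the scatter) is estimated to be small.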

Compound 4, a percentage reported as inhibition, at one concentration (the size of the read-out at that concentration, not a potency): 65.9%
Compound 4: middle estimate off by 3.9 percentage points, on the low side, and the stated range covers the measured number.
By their numbers in this assay, from the lowest: compounds 2, 3, 1 and 4 (each within the scatter of the next).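

In this assay, exchanging methoxy for bromo on an aromatic carbon, at the place para to a large group, removes the only hydrogen-bond acceptor of the substituent and one heavy atom, yet the read-out stays within the scatter (a number 2.5 percentage points higher from compound 3 to compound 4 (within the scatter)). The 4-bromophenyl group also cannot be told apart from the two aryl groups that carry their substituent elsewhere, 2-methylphenyl (a number 8.8 percentage points higher from compound 2 to compound 4 (within the scatter)) and 2-chlorophenyl (a number 1.3 percentage points higher from compound 1 to compound 4 (within the scatter)), so a fourth aryl group, and the first bromo compound, joins the same narrow band. Nothing measured here bears on why these four compounds read so alike.

The compounds shown leave open whether an amine, a carboxylic acid or a longer chain at this place on the aryl ring would move the read-out beyond the scatter, or whether the band would hold with such groups too. They also leave open whether the four compounds would still be indistinguishable on a true potency measure, as a percentage at one concentration is not a potency.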